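This account rests on a few compounds, and the source may have more. Where it says the series, first, only, none or still open, it means among the compounds named here.

The study concerns cytotoxicity on human fibroblasts, measured in an ADME assay on HFF cells (Homo sapiens) for cytotoxicity, read by MTT assay, with a stated time of 72 h; on this read-out higher numbers stand for weaker inhibition and lower numbers for stronger inhibition. Three compounds share a core built around a lactone bearing two benzyloxy groups and a triazole arm. Compound 1 `Cc1ccc(-c2cn(C/C=C3\OC(=O)C(OCc4ccccc4)=C3OCc3ccccc3)nn2)cc1` carries the triazole on a propenyl linker; in this assay compound 1 reaches only the limit of the assay, > 100000 nM, and no number. Compound 2 `CC(C)(C)OC(=O)N1CCN(C(=S)SCc2cn(C[C@H](O)[C@H]3OC(=O)C(OCc4ccccc4)=C3OCc3ccccc3)nn2)CC1` has a hydroxy-bearing linker and a dithiocarbamate on the triazole; in this assay compound 2 gives 60 nM. Among the compounds with values here, compound 3 `COc1ccccc1-c1cn(C[C@H](O)[C@H]2OC(=O)C(OCc3ccccc3)=C2OCc2ccccc2)nn1` keeps that linker with a 2-methoxyphenyl on the triazole and gives 50 nM in this assay, a value that lies within the scatter of the one for compound 2. Compound 4 `O=C1O[C@H]([C@@H](O)Cn2cc(CCO)nn2)C(OCc2ccccc2)=C1OCc1ccccc1` is not yet measured. It differs from compound 3 in one place: 2-hydroxyethyl in place of 2-methoxyphenyl on an aromatic carbon. Within the data shown here, no measured pair covers this change, so the direction must be estimated; a moderate step toward weaker inhibition, a 10-fold higher number from compound 3 to compound 4 (1.00 log units; beyond the scatter), is expected. Compound 4 is thus estimated at 500 nM, with a range from 100 nM to 5000 nM.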

Compound 4, half-maximal inhibitory concentration: 58500 nM
Compound 4: middle estimate off by 120-fold (2.07 log units), on the low side; the whole stated range lies below it.
By their numbers in this assay, from the lowest: compounds 3 and 2 (each within the scatter of the next); then compound 4. At a limit, above all of these: compound 1.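

Replacing 2-methoxyphenyl with 2-hydroxyethyl on this aromatic carbon gives a 1200-fold higher number from compound 3 to compound 4 (3.07 log units; beyond the scatter), so in this assay this one position, with the linker and the rest of the molecule unchanged, can shift the read-out very strongly toward weaker inhibition. The earlier compounds shown here offered no pair differing in one place; this step shows that the hydroxy-bearing linker and the shared core do not by themselves secure a low number. The data shown give no measured basis for explaining the size of this step.

The change removes the aromatic ring and shortens the group at once, and the compounds shown do not separate these two differences. As far as these compounds go, it remains open how a cyclohexyl group, a longer chain ending in hydroxyl or an amine at this position would read.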